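Restoring a hydroxyl to a diol-free amine

This account rests on a few compounds, and the source may have more. Where it says the series, first, only, none or still open, it means among the compounds named here.

Compound 1 `CCCCCCCCc1ccc(CCC(N)(CO)CCCO)cc1` gives 0.085 mg/kg in a functional assay on the whole organism (spleen, spleen) with Rattus norvegicus as the target; on this read-out lower numbers stand for an effect already at smaller amounts and higher numbers for an effect only at larger amounts of compound. Compound 2 `CCCCCCCCc1ccc(CCC(C)(N)CCO)cc1` reaches only the limit of this assay, > 10 mg/kg. The step of an at least 110-fold higher number from compound 1 to compound 2 (2.07 log units; beyond the scatter) is the only measured one bearing on the change at hand, and it sits at the limit of > 10 mg/kg in this assay, at which 1 of the 2 values shown sits. Compound 3 `CCCCCCCCc1ccc(CCC(N)(CCO)CCO)cc1` differs from compound 2 by hydroxymethyl in place of hydrogen on a saturated chain carbon, two bonds along the chain from an amine nitrogen. Since the loss of such a hydroxyl group carried the large step of an at least 110-fold higher number from compound 1 to compound 2 (2.07 log units; beyond the scatter), its return is expected to bring a large step downward, an at least 10-fold lower number from compound 2 to compound 3 (1.00 log units; beyond the scatter). Compound 3 is therefore estimated at 1 mg/kg, between 0.1 mg/kg and 10 mg/kg.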

Compound 3, dose for 50% inhibition: > 10 mg/kg
Compound 3: a limit, no number (the forecaster's own chance of this, stated with the estimate: 25%); middle value at least 10-fold (1.00 log units) from the limit.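

Replacing methyl with 2-hydroxyethyl at this position does not by itself bring back a readable effect, as compound 3 also sits at a limit. Among these compounds, its group has as many heavy atoms as the one in compound 1, of the same kinds, yet the result is an at least 110-fold higher number from compound 1 to compound 3 (2.07 log units; beyond the scatter), so the atom count of this group does not decide the outcome. The step between compound 2 and compound 3 cannot be read: the limit of > 10 mg/kg in this assay, at which 2 of the 3 values shown sit.

Going by these compounds, it remains open whether a hydroxymethyl group paired with a 2-hydroxyethyl chain would give a readable value. On these data alone, the effect of a carboxylic acid in place of either hydroxyl is also open.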